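This account rests on a few compounds, and the source may have more. Where it says the series, first, only, none or still open, it means among the compounds named here.

Measured in a functional assay on MCF7 cells (Homo sapiens) for antiproliferative activity, read by MTT assay, with a stated time of 72 h; on this read-out higher numbers stand for weaker inhibition and lower numbers for stronger inhibition:
- compound 1 `COc1ccc(/C=C2/CN(C)/C(=N/c3ccc(OC)cc3)S2)cc1` gives 8700 nM
- compound 2 `COc1ccc(/C=C2/CN(C)/C(=N/c3ccc(C(F)(F)F)cc3)S2)cc1` gives 24100 nM

Of these two numbers, compound 2 holds the higher, at 24100 nM, and so shows the weaker inhibition. Compound 3 `COc1ccc(/C=C2/CN(C)/C(=N/c3ccc(Cl)cc3)S2)cc1` differs from it in one place, with chloro in place of trifluoromethyl on an aromatic carbon, para to a large group (chloro in place of trifluoromethyl on an aromatic carbon).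

Among the compounds with values here, only one measured step bears on this change, a modest one: a 2.8-fold higher number from compound 1 to compound 2 (0.44 log units; beyond the scatter). In that step, trifluoromethyl replaced methoxy on an aromatic carbon. Within the data shown here, no chloro compound has been measured, so this single step is a weak guide. In this assay, among the measured compounds shown here, a small move toward a lower number is expected, no larger than that step and possibly within the scatter. The estimated step is a 1.6-fold lower number from compound 2 to compound 3 (0.21 log units; within the scatter). Compound 3 is estimated at 15000 nM, with an expected range of 7000 nM to 32000 nM.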

Compound 3, half-maximal inhibitory concentration: 7600 nM
Compound 3: the middle estimate sits 2.0-fold (0.30 log units) above what was measured; the measured number falls inside the stated range.
By their numbers in this assay, from the lowest: compounds 3 and 1 (each within the scatter of the next); then compound 2.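

In this assay, within the data shown here, chloro at this position gives a clearly lower number than trifluoromethyl (a 3.2-fold lower number from compound 2 to compound 3 (0.50 log units; beyond the scatter)), so the one earlier step now has a second step beside it. Methoxy and chloro stand level (a 1.1-fold lower number from compound 1 to compound 3 (0.06 log units; within the scatter)), which leaves trifluoromethyl as the only one of the three groups here that sets its compound apart, with compound 1 and compound 3 sharing the stronger inhibition. No measurement is at hand that could explain this difference between the groups.

The compounds shown leave open whether an amine, a carboxylic acid or a hydroxyl at this place would stand with methoxy and chloro, stand with trifluoromethyl, or give a number unlike either. They also leave open whether the same picture would hold if the methoxy on the other aromatic ring of the shared core gave way to another group.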